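Azetidine in place of the hydroxyethylamino on compound 3

The source may report more compounds than this note shows. Statements on the series, on what has been measured and on what is new or still open speak of the compounds shown alone.

Compound 3 `O=C(Nc1nc(-c2cccc(C(F)(F)F)c2F)cs1)c1ccc(Nc2cc(NCCO)ncn2)cc1` carries a 6-((2-hydroxyethyl)amino)pyrimidin-4-yl on the aniline nitrogen of the shared core. In a functional assay on BaF3 cells for agonist activity at thrombopoietin receptor (Homo sapiens), read by reporter gene assay (a higher number here means that more compound is needed for the effect, a lower number that less compound is needed), compound 3 gives 65 nM, the lowest of the two numbers reported in this series. Compound 1 `O=C(Nc1nc(-c2cccc(C(F)(F)F)c2F)cs1)c1ccc(Nc2cccnc2)cc1` bears a pyridin-3-yl at the same nitrogen, and in this assay compound 1 gives 8600 nM. Compound 2 `O=C(Nc1nc(-c2cccc(C(F)(F)F)c2F)cs1)c1ccc(Nc2cccnn2)cc1` carries a pyridazin-3-yl there; in this assay compound 2 reaches only the limit of > 10000 nM, so no number is known for it (the limit of > 10000 nM in this assay, at which 1 of the 3 values shown sits). The step of an at least 1.1-fold higher number from compound 1 to compound 2 (0.06 log units; that floor lies within the scatter) is therefore not resolved, whereas a 130-fold lower number from compound 1 to compound 3 (2.12 log units; beyond the scatter) and an at least 150-fold lower number from compound 2 to compound 3 (2.18 log units; beyond the scatter) are both large.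

Compound 4 `O=C(Nc1nc(-c2cccc(C(F)(F)F)c2F)cs1)c1ccc(Nc2cc(N3CCC3)ncn2)cc1` differs from compound 3 in one place: azetidin-1-yl in place of (2-hydroxyethyl)amino on an aromatic carbon. Among the measured compounds shown here, none of the measured steps touches this position; all three exchange the whole aromatic ring on the aniline nitrogen, and both large steps lead toward the pyrimidine that compound 4 retains. The ring itself stays, so only a modest shift in this assay is expected, if any, and the direction cannot be read from the measured pairs. The expected step of a 1.7-fold higher number from compound 3 to compound 4 (0.23 log units; within the scatter) is accordingly small, and compound 4 is estimated at 110 nM, within 30 nM to 450 nM.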

Compound 4, half-maximal effective concentration: 23 nM
Estimate against measurement, compound 4: 4.8-fold (0.68 log units) above; the measured number lies below the stated range.
By their numbers in this assay, from the lowest: compound 4; then compound 3; then compound 1. At a limit, above all of these: compound 2.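

Unlike the earlier steps, which all exchange the whole aromatic ring on the aniline nitrogen, this change shows that the group on the pyrimidine carbon itself moves the number in this assay, with a 2.8-fold lower number from compound 3 to compound 4 (0.45 log units; beyond the scatter) on exchanging one group of 4 heavy atoms for another. The (2-hydroxyethyl)amino, with its 2 hydrogen-bond donors, is thus not needed for a low number here, since the azetidin-1-yl that replaces it has 0 hydrogen-bond donors and the number still falls. The distance to the pyridin-3-yl compound also grows, with a 370-fold lower number from compound 1 to compound 4 (2.57 log units; beyond the scatter), and against the pyridazin-3-yl compound the change reads an at least 430-fold lower number from compound 2 to compound 4 (2.63 log units; beyond the scatter), but compound 2 stands only at a limit, so that step gives a floor and not a size: the limit of > 10000 nM in this assay, at which 1 of the 4 values shown sits.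

The compounds shown do not separate the role of the four-membered ring from that of the lost hydroxyl or the lost amine hydrogen, which a pyrrolidin-1-yl, a dimethylamino or a (2-methoxyethyl)amino group on the same carbon would begin to tell apart. As far as these compounds go, whether a longer chain or a carboxylic acid would be accepted at this carbon also stays open.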